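Notes on a bromo for chloro exchange

This account rests on a few compounds, and the source may have more. Where it says the series, first, only, none or still open, it means among the compounds named here.

Values in a functional assay on U-373MG ATCC cells (Homo sapiens) for cytotoxicity, read by MTT assay, with a stated time of 72 h; on this read-out lower numbers stand for stronger inhibition and higher numbers for weaker inhibition:
compound 1 `CSc1nc(Cl)c(C(=O)c2ccccc2)s1` gives > 100000 nM
compound 2 `CSc1nc(Br)c(C(=O)c2ccccc2)s1` gives 89000 nM
compound 3 `O=C(c1ccccc1)c1sc(N2CCCC2)nc1Cl` gives 82000 nM

Compound 1 gives > 100000 nM, which is a limit of the assay. Compound 3 (82000 nM) stands within the scatter of compound 2 (89000 nM). Compound 4 `O=C(c1ccccc1)c1sc(N2CCCC2)nc1Br` carries bromo in place of chloro on an aromatic carbon, next to the ring nitrogen (bromo in place of chloro on an aromatic carbon). The same exchange was measured as a step (an at least 1.1-fold lower number from compound 1 to compound 2 (0.05 log units; that floor lies within the scatter)), and pyrrolidin-1-yl in place of methylsulfanyl gave a similar one (an at least 1.2-fold lower number from compound 1 to compound 3 (0.08 log units; that floor lies within the scatter)). Neither floor leaves the scatter, so in this assay no step beyond the scatter is expected (a 1.1-fold lower number from compound 3 to compound 4 (0.04 log units; within the scatter)). Compound 4 is estimated at 75000 nM (expected range 40000 nM to 100000 nM).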

Compound 4, half-maximal inhibitory concentration: > 100000 nM
Compound 4 gave a limit, no number; the forecaster's own chance of this, stated with the estimate: 20%; middle value at least 1.3-fold (0.12 log units) away from the limit.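

In this assay, bromo in place of chloro on this aromatic carbon gives an at least 1.2-fold higher number from compound 3 to compound 4 (0.08 log units; that floor lies within the scatter), so with a pyrrolidin-1-yl group present the exchange yields no lower number: the same change on two cores in this assay, an at least 1.1-fold lower number (0.05 log units; that floor lies within the scatter) from compound 1 to compound 2 and an at least 1.2-fold higher number (0.08 log units; that floor lies within the scatter) from compound 3 to compound 4; the limit leaves it open whether they differ. Pyrrolidin-1-yl in place of methylsulfanyl with bromo present gives an at least 1.1-fold higher number from compound 2 to compound 4 (0.05 log units; that floor lies within the scatter), which also yields no lower number: the same change on two cores in this assay, an at least 1.2-fold lower number (0.08 log units; that floor lies within the scatter) from compound 1 to compound 3 and an at least 1.1-fold higher number (0.05 log units; that floor lies within the scatter) from compound 2 to compound 4; the limit leaves it open whether they differ. Neither exchange is shown to move the read-out beyond the scatter, and the series now sits largely at the edge of the read-out: the limit of > 100000 nM in this assay, at which 2 of the 4 values shown sit. Still open, as far as these compounds go, is whether an amine or a carboxylic acid in place of the halogen on this aromatic carbon would give a number clearly apart from these values.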